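Chain change from compound 2 to compound 3

The compounds below may be only part of what the source reports. "The series", "measured", "known", "first", "only" and "open" are said of these compounds alone.

Measured in a functional assay on RAW264.7 cells (Mus musculus) for inhibition, read by Griess assay, with a stated time of 20 h; a lower number here means a stronger inhibitor, a higher number a weaker inhibitor:
Compound 1 `CCCCCCc1cn(-c2ccc(O)c(C(=O)NCCC)c2)nn1`: 19700 nM
Compound 2 `CC(C)CCc1cn(-c2ccc(O)c(C(=O)N3CCCCC3)c2)nn1`: > 20000 nM (a limit of the assay, not a number)

Compound 2 stands at a limit, > 20000 nM, so it has no number from which to count a step. Compound 3 `CCCCCCc1cn(-c2ccc(O)c(C(=O)N3CCCCC3)c2)nn1` is not yet measured. It differs from compound 2 in the side chain: butyl in place of isopropyl on a saturated chain carbon, two bonds along the chain from an aromatic carbon. The same difference reads isopentyl to hexyl. Compound 1 carries the hexyl with a different amide, and in this assay compound 1 gives 19700 nM. For the measured compounds named here, no measured step isolates this change, so the expectation rests on that single value. A small shift toward stronger inhibition is expected, estimated as an at least 1.3-fold lower number from compound 2 to compound 3 (0.12 log units; that floor lies within the scatter), and a result at the limit remains possible. Compound 3 is estimated at 15000 nM, with an expected range of 6000 nM to 30000 nM.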

Compound 3, half-maximal inhibitory concentration: > 20000 nM
Compound 3: only a limit was reported (the forecaster's own chance of this, stated with the estimate: 45%); middle value at least 1.3-fold (0.12 log units) away from the limit.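

In this assay compound 3 sits at a limit of the assay, > 20000 nM, which is not a number. On the piperidin-1-yl amide, then, hexyl in place of isopentyl yields no measurable value, and the step between the two limits cannot be read. With the hexyl chain held constant, piperidin-1-yl in place of propylamino on the carbonyl carbon gives an at least 1.0-fold higher number from compound 1 to compound 3 (0.00 log units; that floor lies within the scatter), a floor that fixes no direction for the amide change, and the series now reads as follows: the limit of > 20000 nM in this assay, at which 2 of the 3 values shown sit.

From the compounds shown here alone, only compound 1 carries a number, and how far inhibition can move from that value in either direction remains open. A longer chain such as octyl in place of hexyl, or a carboxylic acid in place of the amide, would test whether either position can give a value clear of the limit.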